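The source may hold more compounds than are shown below. What is called first, only, known or untested is meant among the compounds shown, and "the series" means these compounds.

Series notes. Compound 1 `COc1ccc2oc(C(=O)N(Cc3cccs3)c3ccn[nH]3)cc2c1` and compound 2 `Cc1ccc(OCC(=O)N(CCCO)Cc2cccs2)cc1` have been measured in an assay on HEK293 cells for agonist activity at transient receptor potential cation channel subfamily M member 8 (Homo sapiens), read by fluorescence and calcium flux, with a stated time of 15 min; a higher number here means that more compound is needed for the effect, a lower number that less compound is needed. Compound 1 gives 1.1 nM in this assay, and compound 2 gives 3000 nM. For the measured compounds named here, compound 2 thus stands at the higher of the two numbers, with compound 1 as its only neighbour at a lower number, the gap lying well beyond the scatter. Going by the values given here, the two compounds differ in several places at once, so no single step can be drawn between them.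

Compound 3 `Cc1ccc(OCC(=O)N(Cc2cccs2)c2ccncc2)cc1`, not yet measured, is compound 2 altered in one place: pyridin-4-yl in place of 3-hydroxypropyl on an amide-type nitrogen. The change puts a six-membered aromatic ring on the amide-type nitrogen, which compound 1 also carries as a ring on its amide-type nitrogen, while the rest of compound 2 stays as it is. In this assay the step of a 10-fold lower number from compound 2 to compound 3 (1.00 log units; beyond the scatter) is expected to be downward and beyond the scatter. Compound 3 is estimated at 300 nM, within 30 nM to 3000 nM.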

Compound 3, half-maximal effective concentration: 52 nM
Compound 3: middle estimate off by 5.8-fold (0.76 log units), on the high side; measured number inside the range.
By their numbers in this assay, from the lowest: compound 1; then compound 3; then compound 2.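

In this assay, the substituent on the amide-type nitrogen of compound 2 has a large bearing on the read-out: pyridin-4-yl in place of 3-hydroxypropyl gives a 58-fold lower number from compound 2 to compound 3 (1.76 log units; beyond the scatter) and is a large step. This position therefore tolerates a six-membered aromatic ring without a hydrogen-bond donor in place of a ringless chain that carries one, and less compound is needed for the effect. Nothing available bears on why this step is so large.

The change removes the hydroxyl-bearing chain and introduces the ring at once, so a plain propyl chain or a phenyl ring on the same nitrogen would be needed to separate the two contributions. The compounds shown also leave open whether the ring nitrogen matters and where it is best placed, a question that pyridin-3-yl or pyridin-2-yl at this position would address.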